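A few compounds are considered here, and "the series" means these few. Any claim that something is new, unique, unknown or untested is made for them only; others in the source may bear on it.

Three compounds share one core and differ only in the group carried on a saturated chain carbon bound to an aromatic carbon. Compound 1 `COc1cc(Cc2cc(C)nn(CC(=O)Nc3ccc(Br)cc3)c2=O)cc(OC)c1` carries 3,5-dimethoxyphenyl there. In an assay on HL-60 cells for agonist activity at N-formyl peptide receptor 3 (Homo sapiens), read by calcium flux (on this read-out lower numbers stand for an effect already at smaller amounts and higher numbers for an effect only at larger amounts of compound), compound 1 gives only a limit, > 50000 nM. Compound 2 `Cc1cc(Cc2ccc(C(F)(F)F)cc2)c(=O)n(CC(=O)Nc2ccc(Br)cc2)n1` carries 4-(trifluoromethyl)phenyl. In this assay compound 2 likewise gives only a limit, > 50000 nM. Compound 3 `Cc1cc(Cc2ccsc2)c(=O)n(CC(=O)Nc2ccc(Br)cc2)n1` carries thiophen-3-yl. In this assay compound 3 too gives only a limit, > 50000 nM. Going by the values given here, compound 3 thus stands where every compound measured so far stands, at the limit of > 50000 nM in this assay, at which 3 of the 3 values shown sit. The steps a step that the two limits leave unreadable from compound 1 to compound 2, a step that the two limits leave unreadable from compound 1 to compound 3 and a step that the two limits leave unreadable from compound 2 to compound 3 cannot be sized for that reason. Compound 4 `Cc1cc(Cc2cccs2)c(=O)n(CC(=O)Nc2ccc(Br)cc2)n1` differs from compound 3 by thiophen-2-yl in place of thiophen-3-yl on a saturated chain carbon bound to an aromatic carbon. Among the compounds with values here, no measured step offers a readable size to lean on, and each ends at the same limit. Compound 4 is therefore expected to sit at that limit as well. The expected step is a number no higher from compound 3 to compound 4 (the limit leaves the size open), nothing beyond the scatter. The estimate for compound 4 is 50000 nM, in the range 20000 nM to 100000 nM.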

Compound 4, half-maximal effective concentration: 10200 nM
Beside the measured number, compound 4's estimate is 4.9-fold (0.69 log units) above it, and the stated range ends above it.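

In this assay, thiophen-2-yl in place of thiophen-3-yl, the same atoms joined differently, gives an at least 4.9-fold lower number from compound 3 to compound 4 (0.69 log units; beyond the scatter), so the group on this saturated chain carbon can turn a compound with no readable effect into one with a measurable effect through the point of ring attachment alone. Thiophen-2-yl also stands apart from the two larger groups, with an at least 4.9-fold lower number from compound 2 to compound 4 (0.69 log units; beyond the scatter) and an at least 4.9-fold lower number from compound 1 to compound 4 (0.69 log units; beyond the scatter). Compound 4 is the only compound here with a measured number rather than a limit: the limit of > 50000 nM in this assay, at which 3 of the 4 values shown sit.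

Going by these compounds, the true sizes of these steps remain open, and the steps among compound 1, compound 2 and compound 3 cannot be read at all. Also open, on these data alone, is how the number would respond to a furan-2-yl ring, or to a methyl group or an amine on the thiophen-2-yl ring.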